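Trading an Isopropylphenyl Ring for a Difluorophenyl Ring

A few compounds are considered here, and "the series" means these few. Any claim that something is new, unique, unknown or untested is made for them only; others in the source may bear on it.

Of the compounds shown here, three built on one shared core have been tested in an assay for displacement of a labelled ligand from melanin-concentrating hormone receptor 1 (Homo sapiens), read by fluorescence; on this read-out higher numbers stand for weaker inhibition and lower numbers for stronger inhibition. Compound 1 `CC(=O)Nc1cccc(C2CCN(CCCn3c(-c4ccccc4)nc4ccccc43)CC2)c1` gives 2 nM. Compound 2 `CC(=O)Nc1cccc(C2CCN(CCCn3c(-c4ccccc4Cl)nc4ccccc43)CC2)c1`, which carries a chloro group in place of a hydrogen on an aromatic carbon, gives 10 nM. Compound 3 `CC(=O)Nc1cccc(C2CCN(CCCn3c(-c4ccc(C(C)C)cc4)nc4ccccc43)CC2)c1`, which carries an isopropyl group in place of a hydrogen on an aromatic carbon, gives 60 nM, the highest of the three numbers and therefore the weakest binder of this small set.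

Both measured steps point the same way: a 5.0-fold higher number from compound 1 to compound 2 (0.70 log units; beyond the scatter), and a 30-fold higher number from compound 1 to compound 3 (1.48 log units; beyond the scatter). For the measured compounds named here, the second step, the large one, is the one most relevant to compound 4 `CC(=O)Nc1cccc(C2CCN(CCCn3c(-c4ccc(F)c(F)c4)nc4ccccc43)CC2)c1`. It is the step in which the isopropyl group arrived and the number rose. The change now considered is 3,4-difluorophenyl in place of 4-isopropylphenyl on an aromatic carbon. The group leaving is the one whose arrival raised the number so sharply, and the incoming difluorophenyl is closer in heavy-atom count to the plain phenyl of compound 1, which gave 2 nM, and to the chlorophenyl of compound 2, which gave 10 nM. The step is therefore expected to be a 7.5-fold lower number from compound 3 to compound 4 (0.88 log units; beyond the scatter). For compound 4 in this assay the estimate is 8 nM, with a likely range from 2.5 nM to 30 nM.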

Compound 4, half-maximal inhibitory concentration: 4 nM
Beside the measured number, compound 4's estimate is 2.0-fold (0.30 log units) above it; measured number inside the range.
By their numbers in this assay, from the lowest: compounds 1 and 4 (each within the scatter of the next); then compound 2; then compound 3.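

The rise seen with compound 3 does not apply to every substituted phenyl ring at this position, on the ring carbon between two ring nitrogen atoms: swapping 4-isopropylphenyl for 3,4-difluorophenyl reverses most of it (a 15-fold lower number from compound 3 to compound 4 (1.18 log units; beyond the scatter)). The new ring also beats 2-chlorophenyl (a 2.5-fold lower number from compound 2 to compound 4 (0.40 log units; beyond the scatter)), whereas its difference from plain phenyl stays within the scatter (a 2.0-fold higher number from compound 1 to compound 4 (0.30 log units; within the scatter)), so in this assay a phenyl ring carrying two fluorines can be told apart from neither a gain nor a loss. Nothing available here explains why these rings differ.

Going by these compounds, it remains open whether one fluorine alone, at either of these ring positions, would match the pair. On these data alone, the fate of a phenyl ring carrying an amine or a carboxylic acid at this position also remains unknown.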